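The source may hold more compounds than are shown below. What is called first, only, known or untested is meant among the compounds shown, and "the series" means these compounds.

Two members of this series have been examined in a functional assay on T47D cells (Homo sapiens) for cytotoxicity, read by sulforhodamine B assay, with a stated time of 48 h; a lower number here means a stronger inhibitor, a higher number a weaker inhibitor. Compound 1 `Cc1noc(NS(=O)(=O)c2ccc(N/C=C\C(=O)c3cc4ccccc4oc3=O)cc2)c1C` gives 68400 nM in this assay, and compound 2 `O=C(/C=C\Nc1ccc(S(=O)(=O)Nc2ccccn2)cc1)c1cc2ccccc2oc1=O` gives 37600 nM. For the measured compounds named here, the only step between them, a 1.8-fold lower number from compound 1 to compound 2 (0.26 log units; within the scatter), does not rise above the scatter, so compound 2 stands at the lower of the two numbers without being separable from compound 1. Compound 3 `O=C(/C=C\Nc1ccc(S(=O)(=O)Nc2ncccn2)cc1)c1cc2ccccc2oc1=O` has not yet been measured; it differs from compound 2 by pyrimidin-2-yl in place of pyridin-2-yl on a sulfonamide nitrogen. Going by the values given here, no measured step concerns this exact exchange; the nearest guide is the step from compound 1 to compound 2, which swapped the group on the same sulfonamide nitrogen and stayed within the scatter. Compound 3 is therefore expected to sit close to compound 2 in this assay, with an estimated step of a 1.1-fold higher number from compound 2 to compound 3 (0.03 log units; within the scatter). The expected value for compound 3 is 40000 nM, with a range from 15000 nM to 110000 nM.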

Compound 3, half-maximal inhibitory concentration: 75200 nM
Beside the measured number, compound 3's estimate is 1.9-fold (0.27 log units) below it, within the range that was stated.
By their numbers in this assay, from the lowest: compounds 2, 1 and 3 (each within the scatter of the next).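

In this assay, the exchange of a ring carbon for a nitrogen in the group on the sulfonamide nitrogen, pyrimidin-2-yl in place of pyridin-2-yl, gives a 2.0-fold higher number from compound 2 to compound 3 (0.30 log units; within the scatter), and pyrimidin-2-yl in place of 3,4-dimethyl-1,2-oxazol-5-yl gives a 1.1-fold higher number from compound 1 to compound 3 (0.04 log units; within the scatter). With a third group now in place, all three compounds lie within the scatter of one another, so the added ring nitrogen and hydrogen-bond acceptor of pyrimidin-2-yl leave no separable mark at this position. No evidence bearing on this result is available.

All three groups shown are rings, so the compounds leave open whether an open-chain group there, such as a methyl or a longer alkyl chain, would give a step beyond the scatter. Going by these compounds, whether a carboxylic acid or an amine carried on the ring would do so also remains open.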